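The source may report more compounds than this note shows. Statements on the series, on what has been measured and on what is new or still open speak of the compounds shown alone.

Measured compounds in an ADME assay on TZM cells (Homo sapiens) for cytotoxicity, read by XTT assay, with a stated time of 4 days; a lower number here means that less compound is tolerated, a higher number that more compound is tolerated:
Compound 1 `Cc1cc(CCC#N)cc(C)c1Oc1cc(Nc2ccc(C#N)cc2)c(N)cc1S(N)(=O)=O` gives 11100 nM.
Compound 2 `Cc1cc(CCC#N)cc(C)c1Oc1cc(Nc2ccc(C#N)cc2)c(N)cc1C(N)=O` gives a limit of the assay, > 9400 nM.
Compound 3 `Cc1cc(/C=C/C#N)cc(C)c1Oc1cc(Nc2ccc(C#N)cc2)c(N)cc1[N+](=O)[O-]` gives a limit of the assay, > 24400 nM.

Compound 2 therefore stands at a limit in this assay rather than at a number, and of the three values shown one further value is also a limit. Compound 1 is the only one of the three with a read number, and it sits in the same region as the two limits.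

The new compound 4 `Cc1cc(CCC#N)cc(C)c1Oc1cc(Nc2ccc(C#N)cc2)c(N)cc1N` differs from compound 2 in one place: amino in place of carbamoyl on an aromatic carbon

Among the compounds with values here, only one measured step touches this position, a step that the limit leaves unreadable from compound 1 to compound 2, and its size cannot be read because of the limit of > 9400 nM in this assay, at which 1 of the 3 values shown sits. Within the data shown here, no measured step thus gives a size for this kind of change, and nothing among the three values shown points in either direction. The expectation for compound 4 is therefore a step that the limit leaves unreadable from compound 2 to compound 4, that is, none beyond the scatter. The estimate for compound 4 in this assay is 15000 nM, in the range 6000 nM to 40000 nM, with a good chance that the assay again reports only a limit.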

Compound 4, half-maximal cytotoxic concentration: > 25000 nM
Compound 4: only a limit was reported (the forecaster's own chance of this, stated with the estimate: 50%); middle value at least 1.6-fold (0.22 log units) away from the limit.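

In this assay compound 4, which carries amino on this aromatic carbon, gives > 25000 nM, and this is a limit of the assay and not a number. Amino in place of sulfamoyl gives an at least 2.2-fold higher number from compound 1 to compound 4 (0.35 log units; beyond the scatter), which is the first step at this position with a readable size, and it points towards more compound being tolerated. The steps that involve the carbamoyl of compound 2 cannot be read, so carbamoyl and amino cannot be ranked against each other, because compound 2 stands at a limit: the limit of > 9400 nM in this assay, at which 1 of the 4 values shown sits.

Still open, as far as these compounds go, is how far compound 4 really lies from compound 1, since the step has only a lower bound, and how compound 2 relates to either of them. Also open, from the compounds shown here alone, is whether another group on this aromatic carbon, such as a carboxylic acid or a methylamino group, would give a read number in this assay or would again stand at a limit.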